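Adding one oxygen to a sulfur side group

The source may hold more compounds than are shown below. What is called first, only, known or untested is meant among the compounds shown, and "the series" means these compounds.

In a functional assay (Homo sapiens) for inhibition (a lower number here means a stronger inhibitor, a higher number a weaker inhibitor), compound 3 `CSc1cc(CSc2nc(-c3ccc(F)cc3)c(-c3ccncc3)[nH]2)ccc1O` gives 280 nM, compound 1 `CS(=O)(=O)c1ccc(CSc2nc(-c3ccc(F)cc3)c(-c3ccncc3)[nH]2)cc1` gives 330 nM and compound 2 `CSc1ccccc1CSc1nc(-c2ccc(F)cc2)c(-c2ccncc2)[nH]1` gives 6700 nM. Compound 3 therefore sits level with one neighbour and well clear of the other: there is a 1.2-fold lower number from compound 1 to compound 3 (0.07 log units; within the scatter), and a 24-fold lower number from compound 2 to compound 3 (1.38 log units; beyond the scatter). Compound 4 `C[S+]([O-])c1cc(CSc2nc(-c3ccc(F)cc3)c(-c3ccncc3)[nH]2)ccc1O` alters a single group on an aromatic carbon: a group of 3 heavy atoms (1 carbon, 1 oxygen, 1 sulfur; no ring) in place of a group of 2 heavy atoms (1 carbon, 1 sulfur; no ring), on an aromatic carbon. For the measured compounds named here, no measured step makes this exact change, so the guidance is indirect. The closest hint is compound 1, whose 4-(methylsulfonyl)phenyl group also carries oxygen on sulfur and which gives 330 nM. No shift beyond the scatter is therefore expected, and the estimated step is a 1.3-fold higher number from compound 3 to compound 4 (0.10 log units; within the scatter). For compound 4 the expected value is 350 nM, within an estimated range of 110 nM to 1100 nM.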

Compound 4, half-maximal inhibitory concentration: 2300 nM
Compound 4: the middle estimate sits 6.6-fold (0.82 log units) below what was measured; measured number outside the range, above it.
By their numbers in this assay, from the lowest: compounds 3 and 1 (each within the scatter of the next); then compound 4; then compound 2.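

Adding one oxygen to the sulfur of the methylsulfanyl group is not a neutral change at this position: in this assay there is an 8.2-fold higher number from compound 3 to compound 4 (0.91 log units; beyond the scatter). Oxygen on sulfur is thus no guarantee of a low number, as there is also a 7.0-fold higher number from compound 1 to compound 4 (0.84 log units; beyond the scatter), although compound 4 still improves on the 2-(methylsulfanyl)phenyl compound, with a 2.9-fold lower number from compound 2 to compound 4 (0.46 log units; beyond the scatter). Nothing measured here explains the loss. From the compounds shown here alone, whether a methoxy or ethylsulfanyl group in this place, ortho to a hydroxy group, would keep the number of compound 3 remains open.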